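Substituent change on the shared core: compounds 2 and 3

The source may hold more compounds than are shown below. What is called first, only, known or untested is meant among the compounds shown, and "the series" means these compounds.

Compounds measured:
compound 1 `CC(C(=O)NCc1ccc(C(F)(F)F)nc1NCc1ccc(Cl)cc1)c1ccc(NS(C)(=O)=O)c(F)c1` — 414 nM
compound 2 `CC(C(=O)NCc1ccc(C(F)(F)F)nc1NCc1cccnc1)c1ccc(NS(C)(=O)=O)c(F)c1` — "not active" (no number reported)

In a functional assay on CHO-K1 cells for antagonist activity at transient receptor potential cation channel subfamily V member 1 (Homo sapiens), read by FLIPR (on this read-out higher numbers stand for weaker inhibition and lower numbers for stronger inhibition), compound 1 gives 414 nM. In this assay, for the measured compounds named here, compound 2 is recorded as "not active" (no number reported), so no number stands for it and it cannot be placed on the scale; the two values show only that compound 1 has a measurable half-maximal inhibitory concentration and compound 2 does not. No step between measured compounds is shown for this pair.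

Compound 3 `CC(C(=O)NCc1ccc(C(F)(F)F)nc1N1CCCC1)c1ccc(NS(C)(=O)=O)c(F)c1` has not been measured in this assay. It differs from compound 2 in one place: pyrrolidin-1-yl in place of ((pyridin-3-yl)methyl)amino on an aromatic carbon. With compound 2 carrying no number, no step size or direction in this assay can be anchored; the expectation is that the change brings compound 3 to a measurable but weak inhibition, a reading expected weaker than compound 1 shows. Compound 3 is estimated at 2500 nM, range 500 nM to 15000 nM.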

Compound 3, half-maximal inhibitory concentration: 211 nM
Compound 3: middle estimate off by 12-fold (1.07 log units), on the high side; the measured number lies below the stated range.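

In this assay, pyrrolidin-1-yl in place of (4-chlorobenzyl)amino gives a 2.0-fold lower number from compound 1 to compound 3 (0.29 log units; within the scatter), so this position holds a measurable inhibition with either group, despite the difference in ring and in size. Compound 2 is recorded as "not active" while compound 3 gives 211 nM, and since pyrrolidin-1-yl carries no hydrogen-bond donor, a measurable number here does not depend on a donor at this position. No measurement bearing on the reason for these readings is available.

Unsubstituted benzylamino would show whether the "not active" record of compound 2 goes with its pyridin-3-yl ring or with the absence of the 4-chlorophenyl ring. Piperidin-1-yl, morpholin-4-yl and dimethylamino would show how far the reading of compound 3 extends to other amines without a hydrogen on the nitrogen.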